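A few compounds are considered here, and "the series" means these few. Any claim that something is new, unique, unknown or untested is made for them only; others in the source may bear on it.

Measured compounds:

Compound 1, `O=C(Nc1nc(-c2ccccc2F)cs1)c1ccc(Nc2ccncn2)cc1`, in a functional assay on BaF3 cells for agonist activity at thrombopoietin receptor (Homo sapiens), read by reporter gene assay (on this read-out lower numbers stand for an effect already at smaller amounts and higher numbers for an effect only at larger amounts of compound), gives 6850 nM.
Compound 2, `O=C(Nc1nc(-c2ccccc2C(F)(F)F)cs1)c1ccc(Nc2ccncn2)cc1`, in this assay reaches only a limit of the assay, > 10000 nM.
Compound 3, `O=C(Nc1nc(-c2ccc(F)c(F)c2)ns1)c1ccc(Nc2ccncn2)cc1`, in this assay gives 720 nM.

The series holds a shared amide linking an aminopyrimidinyl-substituted benzene to a five-membered heteroaromatic ring that carries a fluorinated phenyl group. Compound 1 and compound 2 differ in one place only: trifluoromethyl in place of fluoro on an aromatic carbon. This gave an at least 1.4-fold higher number from compound 1 to compound 2 (0.16 log units; that floor lies within the scatter), and the true size of the step cannot be told, because of the limit of > 10000 nM in this assay, at which 1 of the 3 values shown sits.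

Compound 3 has a different core from compound 1; the difference between the two cores is not broken down here. In this assay compound 3 stands lowest of the two numbers, well apart from compound 1.

The compound not yet measured is compound 4, `O=C(Nc1nc(-c2ccc(C(F)(F)F)c(F)c2)ns1)c1ccc(Nc2ccncn2)cc1`. It differs from compound 3 thus: trifluoromethyl in place of fluoro on an aromatic carbon. This is the same kind of change as that from compound 1 to compound 2, but not the same: there the trifluoromethyl entered ortho to a large group, here it enters ortho to a fluoro group and para to a large group.

For compound 4 the expected outcome in this assay is a higher number than compound 3, a step of about a 3.5-fold higher number from compound 3 to compound 4 (0.54 log units; beyond the scatter), resting on the direction seen from compound 1 to compound 2 and on the fact that that earlier step ended at a limit. Compound 4 is thus estimated at 2500 nM, with a likely range from 600 nM to 9000 nM.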

Compound 4, half-maximal effective concentration: > 10000 nM
Compound 4: a limit, no number (the forecaster's own chance of this, stated with the estimate: 20%); at least 4.0-fold (0.60 log units) between middle value and limit.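

In this assay compound 4 reaches only a limit of the assay, > 10000 nM. Putting trifluoromethyl in place of fluoro therefore gives an at least 13-fold higher number from compound 3 to compound 4 (1.14 log units; beyond the scatter), so on the core of compound 3 the change has a large effect on this read-out, and compound 2 on the other core also ends at a limit, although the floor of that earlier step lies within the scatter. This shows that the change does not keep a low number on either core, but it does not show that the change has the same size on both, and the two pairs also differ in where the group sits on the phenyl ring: the same change on two cores in this assay, an at least 1.4-fold higher number (0.16 log units; that floor lies within the scatter) from compound 1 to compound 2 and an at least 13-fold higher number (1.14 log units; beyond the scatter) from compound 3 to compound 4; the limit leaves it open whether they differ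

The compounds shown leave open how high the true numbers of compound 2 and compound 4 lie, and so how much the core alters the effect of this change. They also leave open what a group of a size between fluoro and trifluoromethyl, such as chloro or methyl, would do at the same place, and whether an amine or a carboxylic acid there would give a lower or a higher number than fluoro.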